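The source may report more compounds than this note shows. Statements on the series, on what has been measured and on what is new or still open speak of the compounds shown alone.

Compound 2 `Cc1cc2c(c(N)nn2C)c(N2CCCCC2)n1` stands lowest of the two numbers in an assay on isolated protein for inhibition of serine/threonine-protein kinase Chk2 (Homo sapiens), read by mobility shift assay, tested at 30 uM (a lower number here means less inhibition, a higher number more inhibition at the concentration tested (going by the name of the read-out)), at 4%; compound 1 `Cc1cc2[nH]nc(N)c2c(N2CCCCC2)n1` gives 33% in this assay. For the measured compounds named here, the single measured step is a number 29 percentage points lower from compound 1 to compound 2 (beyond the scatter), a methyl in place of hydrogen on an aromatic nitrogen.

Compound 3 `Cc1cc2c(cn1)c(N)nn2C` differs from compound 2 by hydrogen in place of piperidin-1-yl on an aromatic carbon. Going by the values given here, no measured step covers removal of the piperidin-1-yl group; the methyl-for-hydrogen step gives no guide to it. Since compound 2 already sits low at 4%, any step is expected to stay within the scatter: a number 1 percentage points higher from compound 2 to compound 3 (within the scatter). Compound 3 is estimated at 5%, in the range -5% to 20%.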

Compound 3, a percentage reported as inhibition, at one concentration (the size of the read-out at that concentration, not a potency): 3%
Estimate against measurement, compound 3: 2 percentage points above; measured number inside the range.
By their numbers in this assay, from the lowest: compounds 3 and 2 (each within the scatter of the next); then compound 1.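

In this assay the removal of piperidin-1-yl gives a number 1 percentage points lower from compound 2 to compound 3 (within the scatter), so with a methyl on the aromatic nitrogen, this aromatic carbon next to the ring nitrogen shows no separation between piperidin-1-yl and hydrogen. Compound 2 already stands low, so this pair cannot show what piperidin-1-yl adds where inhibition is clearer. No evidence on this result is available.

Open, going by these compounds, is whether hydrogen in place of piperidin-1-yl would matter with hydrogen on the aromatic nitrogen, as in compound 1. Also open, on these data alone, is how morpholine or a primary amine on this carbon would read.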